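Carbonyl-attached aryl swaps: from compound 1 to compound 4

This account rests on a few compounds, and the source may have more. Where it says the series, first, only, none or still open, it means among the compounds named here.

Three measured compounds share one core and differ only in the group on the carbonyl carbon. Compound 1 `Cc1ccc(OCC(=O)NNC(=O)c2cc3ccccc3oc2=O)c(C(=O)c2cccc(Cl)c2)c1` gives 67400 nM in a functional assay on DLA cells (Mus musculus) for cytotoxicity, read by LDH release, with a stated time of 48 h; on this read-out lower numbers stand for stronger inhibition and higher numbers for weaker inhibition. Compound 2 `Cc1ccc(OCC(=O)NNC(=O)c2cc3ccccc3oc2=O)c(C(=O)c2ccc(Cl)cc2)c1` gives 60400 nM in this assay, and compound 3 `Cc1ccc(OCC(=O)NNC(=O)c2cc3ccccc3oc2=O)c(C(=O)c2cccc(Br)c2)c1` gives 69800 nM. Compound 1 stands second highest of the three numbers; its nearest neighbour is compound 3, with a 1.0-fold higher number from compound 1 to compound 3 (0.02 log units; within the scatter), and its furthest is compound 2, with a 1.1-fold lower number from compound 1 to compound 2 (0.05 log units; within the scatter). Between the other two the step is a 1.2-fold higher number from compound 2 to compound 3 (0.06 log units; within the scatter). Every step in the set lies within the scatter.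

Compound 4 `Cc1ccc(C(=O)c2cc(C)ccc2OCC(=O)NNC(=O)c2cc3ccccc3oc2=O)cc1` is not yet measured. Its change from compound 1 is 4-methylphenyl in place of 3-chlorophenyl on a carbonyl carbon. Among the compounds with values here, the steps that bear on it are the ring-position change a 1.1-fold lower number from compound 1 to compound 2 (0.05 log units; within the scatter) and the exchange of one halogen for another a 1.0-fold higher number from compound 1 to compound 3 (0.02 log units; within the scatter); both are within the scatter, and neither covers a methyl entering in place of chloro. With that caveat, no step beyond the scatter is expected, so a 1.0-fold lower number from compound 1 to compound 4 (0.02 log units; within the scatter) is the expectation. Compound 4 is accordingly estimated at 65000 nM, with a range from 33000 nM to 130000 nM.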

Compound 4, half-maximal inhibitory concentration: 87200 nM
Compound 4: the middle estimate sits 1.3-fold (0.13 log units) below what was measured; low and high end bracket the measured number.
By their numbers in this assay, from the lowest: compounds 2, 1, 3 and 4 (each within the scatter of the next).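

In this assay, a methyl-bearing ring on the carbonyl carbon behaves like the halogen-bearing rings: 4-methylphenyl in place of 3-chlorophenyl (a 1.3-fold higher number from compound 1 to compound 4 (0.11 log units; within the scatter)) and in place of 3-bromophenyl (a 1.2-fold higher number from compound 3 to compound 4 (0.10 log units; within the scatter)) both leave the number within the scatter. The direct exchange of the ring's halogen for a methyl group (a 1.4-fold higher number from compound 2 to compound 4 (0.16 log units; within the scatter)) also stays within the scatter, so this position has now tolerated a non-halogen group without a step beyond it. No measurement is at hand to explain these results.

Going by these compounds, all four groups are phenyl rings carrying chloro, bromo or methyl, so it remains open whether an amine or a carboxylic acid on that ring, or a cyclohexyl group in its place, would give a step beyond the scatter. On these data alone, whether changes elsewhere on the shared core would do so also remains open.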